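The compounds below may be only part of what the source reports. "The series", "measured", "known", "first", "only" and "open" are said of these compounds alone.

In an ADME assay on WI-38 cells (Homo sapiens) for cytotoxicity, read by MTT assay, with a stated time of 72 h (a lower number here means a stronger inhibitor, a higher number a weaker inhibitor), compound 1 `CC(C)c1cccc(NC(=O)CCc2cccc3c2B(O)OC3)c1` gives 22000 nM and compound 2 `CSc1ccc(-c2cccc(NC(=O)CCc3cccc4c3B(O)OC4)c2)cc1` gives 3800 nM as the lower of the two numbers. Going by the values given here, the one measured step, a 5.8-fold lower number from compound 1 to compound 2 (0.76 log units; beyond the scatter) on exchanging isopropyl for 4-(methylsulfanyl)phenyl, is modest but beyond the scatter. Compound 3 `N#Cc1ccc(-c2cccc(NC(=O)CCc3cccc4c3B(O)OC4)c2)cc1` carries cyano in place of methylsulfanyl on an aromatic carbon, para to a large group (cyano in place of methylsulfanyl on an aromatic carbon), which turns 4-(methylsulfanyl)phenyl into 4-cyanophenyl. The measured step bears only loosely on this change: it exchanged the whole group, whereas here the phenyl stays in place. A smaller step than a 5.8-fold lower number from compound 1 to compound 2 (0.76 log units; beyond the scatter) is therefore expected, with only a slight lean towards a higher number. The expected move is a 1.3-fold higher number from compound 2 to compound 3 (0.12 log units; within the scatter) and should stay within the scatter. For compound 3 the estimated value is 5000 nM within an expected range of 2000 nM to 12000 nM as a working figure.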

Compound 3, half-maximal inhibitory concentration: 12000 nM
The estimate for compound 3 lay 2.4-fold (0.38 log units) below the measured number; the range from low to high includes it.
By their numbers in this assay, from the lowest: compound 2; then compounds 3 and 1 (each within the scatter of the next).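

In this assay the group on the aromatic carbon para to a large group affects the number, not just the presence of the added phenyl: a 3.2-fold higher number from compound 2 to compound 3 (0.50 log units; beyond the scatter) for cyano in place of methylsulfanyl, two groups with the same heavy-atom and acceptor counts. With a 1.8-fold lower number from compound 1 to compound 3 (0.26 log units; within the scatter), 4-cyanophenyl in place of isopropyl gives no change beyond the scatter, so among these three compounds only the 4-(methylsulfanyl)phenyl of compound 2 stands apart from isopropyl. Nothing available explains why methylsulfanyl and cyano differ here.

The compounds shown leave open where an unsubstituted phenyl would fall, and so whether methylsulfanyl lowers the number, cyano raises it, or both. They also leave open how an amine, a carboxylic acid or a longer chain at this position would compare.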